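Fluoro-Bearing Core Tested with a Propargyloxy Group

A few compounds are considered here, and "the series" means these few. Any claim that something is new, unique, unknown or untested is made for them only; others in the source may bear on it.

Compound 1 `C#CCOc1cc(N2C(=O)C3=C(CCCC3)C2=O)ccc1Cl`: 501 nM
Compound 2 `CC(C)OC(=O)c1cc(N2C(=O)C3=C(CCCC3)C2=O)ccc1Cl`: 200 nM
Compound 3 `CC(C)OC(=O)c1cc(N2C(=O)C3=C(CCCC3)C2=O)c(F)cc1Cl`: 79.4 nM

These three compounds were tested in a functional assay on the whole organism for inhibition, with Scenedesmus acutus as the target, with a stated time of 20 h; a higher number here means a weaker inhibitor, a lower number a stronger inhibitor. Compound 3 gives the lowest number of the three, and its nearest neighbour is compound 2, which lies a 2.5-fold lower number from compound 2 to compound 3 (0.40 log units; beyond the scatter) apart; the two cores differ by fluoro in place of hydrogen on an aromatic carbon.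

Compound 4 `C#CCOc1cc(N2C(=O)C3=C(CCCC3)C2=O)c(F)cc1Cl` has not been measured in this assay. It differs from compound 3 by propargyloxy in place of isopropoxycarbonyl on an aromatic carbon. The same kind of change, taken on the core of compound 2, gave a 2.5-fold higher number from compound 2 to compound 1 (0.40 log units; beyond the scatter); the surroundings are not identical, since in compound 4 the site is also para to a fluoro group. If the new core behaves like the old one, the step from compound 3 to compound 4 is expected to be a 2.5-fold higher number from compound 3 to compound 4 (0.40 log units; beyond the scatter), resting on the step from compound 2 to compound 1. Compound 4 is therefore estimated at 200 nM, with a likely range from 100 nM to 400 nM.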

Compound 4, half-maximal inhibitory concentration: 126 nM
Compound 4: middle estimate off by 1.6-fold (0.20 log units), on the high side; the range from low to high includes it.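

Putting propargyloxy in place of isopropoxycarbonyl gives a 1.6-fold higher number from compound 3 to compound 4 (0.20 log units; within the scatter), and in this assay this agrees with the same change on the core of compound 2: the same change on two cores in this assay, a 2.5-fold higher number (0.40 log units; beyond the scatter) from compound 2 to compound 1 and a 1.6-fold higher number (0.20 log units; within the scatter) from compound 3 to compound 4, 1.6-fold (0.20 log units) apart, within the scatter of two such steps. Adding the fluoro group gives a 4.0-fold lower number from compound 1 to compound 4 (0.60 log units; beyond the scatter), and this step also agrees across the two cores: the same change on two cores in this assay, a 2.5-fold lower number (0.40 log units; beyond the scatter) from compound 2 to compound 3 and a 4.0-fold lower number (0.60 log units; beyond the scatter) from compound 1 to compound 4, 1.6-fold (0.20 log units) apart, within the scatter of two such steps. Both changes therefore carried over in these four compounds, but that rests on a single pair of cores and does not show that they would carry over to other cores, nor why they behave this way.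

As far as these compounds go, what remains open is how a carboxylic acid, an amine or a longer ether chain at this place would compare. From the compounds shown here alone, it is also open whether the fluoro step would stay similar alongside such groups.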